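A Fluorine Added to the Phenyl of Compound 3

This account rests on a few compounds, and the source may have more. Where it says the series, first, only, none or still open, it means among the compounds named here.

Of the compounds shown here, three sharing one core have been measured in a functional assay on MCF7 cells (Homo sapiens) for antiproliferative activity, read by sulforhodamine B assay, with a stated time of 48 h; on this read-out higher numbers stand for weaker inhibition of growth and lower numbers for stronger inhibition of growth. Compound 1 `COc1ccc(Cn2cc(CNC(=O)c3cn(-c4ccccc4)nc3-c3ccccc3)nn2)cc1` gives only a limit, > 100000 nM, in this assay. Compound 2 `COc1ccc(Cn2cc(CNC(=O)c3cn(-c4ccccc4)nc3-c3ccccc3)nn2)cc1OC` gives 12600 nM, and compound 3 `COc1cc(Cn2cc(CNC(=O)c3cn(-c4ccccc4)nc3-c3ccccc3)nn2)cc(OC)c1` gives 2400 nM. Compound 3 thus holds the lowest of the two actual numbers, separated from its neighbour by the step of a 5.3-fold lower number from compound 2 to compound 3 (0.72 log units; beyond the scatter). Compound 4 `COc1cc(Cn2cc(CNC(=O)c3cn(-c4ccccc4)nc3-c3ccc(F)cc3)nn2)cc(OC)c1` differs from compound 3 in one place: fluoro in place of hydrogen on an aromatic carbon. For the measured compounds named here, none of the measured steps touches that phenyl; each of them, an at least 7.9-fold lower number from compound 1 to compound 2 (0.89 log units; beyond the scatter), an at least 41-fold lower number from compound 1 to compound 3 (1.61 log units; beyond the scatter) and a 5.3-fold lower number from compound 2 to compound 3 (0.72 log units; beyond the scatter), changes the methoxy pattern of the methoxyphenyl group instead. Going by the values given here, no measured step therefore guides this change, and a step within the scatter, no change at the digits printed from compound 3 to compound 4 (within the scatter), is expected. Compound 4 is estimated at 2400 nM, between 900 nM and 6500 nM.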

Compound 4, concentration for 50% growth inhibition: 2500 nM
The estimate for compound 4 lay 1.0-fold (0.02 log units) below the measured number; measured number inside the range.
By their numbers in this assay, from the lowest: compounds 3 and 4 (each within the scatter of the next); then compound 2. At a limit, above all of these: compound 1.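

Replacing phenyl with 4-fluorophenyl in this assay gives a 1.0-fold higher number from compound 3 to compound 4 (0.02 log units; within the scatter), so the two numbers cannot be told apart. For the compounds shown here, this is the first measured step at this place on the ring, and it shows that a fluoro is tolerated there, whereas the earlier steps in the methoxy pattern all lay beyond the scatter. Going by these compounds alone, a single fluoro is only one group, however, so the result says nothing yet about others at this place, such as an amine or a carboxylic acid. Nothing measured here bears on why the fluoro is tolerated.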